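Working notes: replacing the hydroxyphenyl group of compound 2

A few compounds are considered here, and "the series" means these few. Any claim that something is new, unique, unknown or untested is made for them only; others in the source may bear on it.

- compound 1 `COc1cc(O)cc(O)c1C(=O)/C=C/c1ccc(Cl)cc1` gives 18200 nM in a functional assay on A549 cells (Homo sapiens) for inhibition, read by MTT assay, with a stated time of 72 h; on this read-out higher numbers stand for weaker inhibition and lower numbers for stronger inhibition
- compound 2 `COc1cc(OC)c(C(=O)/C=C/c2ccc(O)cc2)c(OC)c1` gives 49400 nM in this assay

Compound 2 holds the higher of the two numbers, and its gap to compound 1 lies beyond the usual scatter. Compound 3 `COc1cc(OC)c(C(=O)/C=C/c2ccccc2OC)c(OC)c1` carries 2-methoxyphenyl in place of 4-hydroxyphenyl on a double-bonded chain carbon bound to a double-bonded chain carbon. Among the measured compounds shown here, the two measured compounds differ in more than one place, so the series offers no direct precedent for this change in this assay. For the measured compounds named here, the only guide is the span of the two values, and compound 3 is expected to fall near it. A small shift towards a lower number is expected, not clearly beyond the scatter. The estimated change is a 1.6-fold lower number from compound 2 to compound 3 (0.22 log units; within the scatter) for now. Compound 3 is estimated at 30000 nM (range 10000 nM to 80000 nM).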

Compound 3, half-maximal inhibitory concentration: 19800 nM
Beside the measured number, compound 3's estimate is 1.5-fold (0.18 log units) above it; the measured number falls inside the stated range.
By their numbers in this assay, from the lowest: compounds 1 and 3 (each within the scatter of the next); then compound 2.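

In this assay, the series gains its first comparison of compounds that differ in one place: the change to 2-methoxyphenyl on a double-bonded chain carbon bound to a double-bonded chain carbon gives a 2.5-fold lower number from compound 2 to compound 3 (0.40 log units; beyond the scatter), a modest step. The entering group counts 0 hydrogen-bond donors against 1 in the leaving group, so at this place the hydroxyl of 4-hydroxyphenyl is not needed to reach the lower number seen for compound 3. No measurement available here accounts for the step.

The step changes both the substituent and its number on the ring, so these two changes cannot be told apart; 4-methoxyphenyl and 2-hydroxyphenyl at this place would separate them. Also open, on these data alone, is how an amine or a carboxylic acid on this phenyl ring would read in this assay.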